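Chloro for amino on the aniline ring of a quinoxaline sulfone

This account rests on a few compounds, and the source may have more. Where it says the series, first, only, none or still open, it means among the compounds named here.

The series rests on one shared core. Compound 1 `O=S(=O)(c1ccccc1)c1nc2ccccc2nc1Nc1ccccc1` gives 22600 nM in a functional assay on KB cells (Homo sapiens) for cytotoxicity, read by MTT assay, with a stated time of 72 h; a higher number here means a weaker inhibitor, a lower number a stronger inhibitor. Compound 2 `COc1cc(Nc2nc3ccccc3nc2S(=O)(=O)c2ccccc2)cc(OC)c1OC` gives "not determined" (no result reported) in this assay. Compound 3 `Nc1ccc(Nc2nc3ccccc3nc2S(=O)(=O)c2ccccc2)cc1` gives 3400 nM in this assay, the lowest of the two numbers shown; the step of a 6.6-fold lower number from compound 1 to compound 3 (0.82 log units; beyond the scatter) is the only measured step, and it shows amino in place of hydrogen. Compound 4 `O=S(=O)(c1ccccc1)c1nc2ccccc2nc1Nc1ccc(Cl)cc1` differs from compound 3 by chloro in place of amino on an aromatic carbon. Among the measured compounds shown here, no measured step shows chloro entering, so the expectation can only rest on the amino step being undone: the number for compound 4 is expected to rise towards that of compound 1, as a 3.5-fold higher number from compound 3 to compound 4 (0.55 log units; beyond the scatter). Compound 4 is therefore estimated at 12000 nM, within 4000 nM to 35000 nM.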

Compound 4, half-maximal inhibitory concentration: 41200 nM
Compound 4: the middle estimate sits 3.4-fold (0.54 log units) below what was measured; measured number outside the range, above it.
By their numbers in this assay, from the lowest: compound 3; then compounds 1 and 4 (each within the scatter of the next).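

Chloro in place of amino gives a 12-fold higher number from compound 3 to compound 4 (1.08 log units; beyond the scatter) in this assay and so removes the low number that amino had brought. Chloro in place of hydrogen gives a 1.8-fold higher number from compound 1 to compound 4 (0.26 log units; within the scatter) and so leaves compound 4 indistinguishable from compound 1, showing that a substituent on this carbon does not by itself lower the number. Nothing available explains this difference. From the compounds shown here alone, whether a hydroxyl, dimethylamino or acetamido group on this carbon would fall nearer compound 3 or compound 1 remains open.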